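The source may report more compounds than this note shows. Statements on the series, on what has been measured and on what is new or still open speak of the compounds shown alone.

In a functional assay on HT-29 cells (Homo sapiens) for antiproliferative activity, read by MTT assay, with a stated time of 24 h (on this read-out lower numbers stand for stronger inhibition and higher numbers for weaker inhibition), compound 1 `COc1ccc(C(=O)/C=C/c2cccc(F)c2)c2c1C=CC(C)(C)O2` gives only a limit, > 10000 nM. For the measured compounds named here, compound 2 `COc1ccc(C(=O)/C=C/c2ccc(N(C)C)cc2)c2c1C=CC(C)(C)O2` gives 1870 nM, the only exact number so far. Going by the values given here, the one measured step, an at least 5.3-fold lower number from compound 1 to compound 2 (0.72 log units; beyond the scatter), changes the group on the same double-bonded chain carbon and rests on (the limit of > 10000 nM in this assay, at which 1 of the 2 values shown sits). Compound 3 `COc1ccc(/C=C/C(=O)c2ccc(OC)c3c2OC(C)(C)C=C3)cn1` differs from compound 2 by 6-methoxypyridin-3-yl in place of 4-(dimethylamino)phenyl on a double-bonded chain carbon bound to a double-bonded chain carbon. The 4-(dimethylamino)phenyl group that came with the drop in an at least 5.3-fold lower number from compound 1 to compound 2 (0.72 log units; beyond the scatter) leaves again, though a different group enters, so weaker inhibition is expected. The expected change is a 2.4-fold higher number from compound 2 to compound 3 (0.38 log units; beyond the scatter), a higher number. The estimate for compound 3 is 4500 nM, with an expected range from 1300 nM to 10000 nM.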

Compound 3, half-maximal inhibitory concentration: > 10000 nM
Compound 3: only a limit was reported (the forecaster's own chance of this, stated with the estimate: 35%); middle value at least 2.2-fold (0.34 log units) from the limit.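

In this assay, 6-methoxypyridin-3-yl in place of 4-(dimethylamino)phenyl gives an at least 5.3-fold higher number from compound 2 to compound 3 (0.72 log units; beyond the scatter), so of the three groups shown on this double-bonded chain carbon, only 4-(dimethylamino)phenyl yields an exact number. The size of this step is only a minimum, since it rests on a limit: the limit of > 10000 nM in this assay, at which 2 of the 3 values shown sit. The step from compound 1 to compound 3 cannot be read.

From the compounds shown here alone, it remains open whether another amine at this place, such as 4-aminophenyl or 4-(diethylamino)phenyl, would match or improve on compound 2.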